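Series notes: replacing the carboxy group of compound 3

A few compounds are considered here, and "the series" means these few. Any claim that something is new, unique, unknown or untested is made for them only; others in the source may bear on it.

Compound 3 `O=C(CCCCC1CCSS1)NCc1cn(CCCOc2ccc3cc(C(=O)O)c(=O)oc3c2)nn1` stands highest of the three measured compounds; in a functional assay on PC-12 cells (Rattus norvegicus) for cytotoxicity, read by MTT assay, with stated times of 3 h and 2 h, tested at 5 uM (on this read-out higher numbers stand for a stronger effect at the one concentration tested and lower numbers for a weaker effect), compound 3 gives 57%. Compound 1 `CC(=O)c1cc2ccc(OCCCn3cc(CNC(=O)CCCCC4CCSS4)nn3)cc2oc1=O` gives 37.5% and compound 2 `CCOC(=O)c1cc2ccc(OCCCn3cc(CNC(=O)CCCCC4CCSS4)nn3)cc2oc1=O` gives 32.4% in this assay. The measured steps are a number 19.5 percentage points higher from compound 1 to compound 3 (beyond the scatter) and a number 24.6 percentage points higher from compound 2 to compound 3 (beyond the scatter), whereas a number 5.1 percentage points lower from compound 1 to compound 2 (within the scatter). Compound 4 `O=C(CCCCC1CCSS1)NCc1cn(CCCOc2ccc3cc(-c4ccccc4)c(=O)oc3c2)nn1` differs from compound 3 by phenyl in place of carboxy on an aromatic carbon. Going by the values given here, no measured step removes the carbonyl altogether, so a direct precedent is lacking. Still, both steps into compound 3 point to the free carboxy as the carrier of the gain, and its removal is expected to cost about as much, giving a number 24 percentage points lower from compound 3 to compound 4 (beyond the scatter), because compound 1 and compound 2 sit lower by a number 19.5 percentage points higher from compound 1 to compound 3 (beyond the scatter) and a number 24.6 percentage points higher from compound 2 to compound 3 (beyond the scatter). Compound 4 is therefore estimated at 33%, expected within 18% to 50%.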

Compound 4, a percentage reported as activity, at one concentration (the size of the read-out at that concentration, not a potency): 29.8%
Compound 4: middle estimate off by 3.2 percentage points, on the high side, and the stated range covers the measured number.
By their numbers in this assay, from the lowest: compounds 4, 2 and 1 (each within the scatter of the next); then compound 3.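

In this assay, phenyl on this aromatic carbon does not keep the level of carboxy, a number 27.2 percentage points lower from compound 3 to compound 4 (beyond the scatter). Phenyl also sits with the two carbonyl-bearing groups, a number 2.6 percentage points lower from compound 2 to compound 4 (within the scatter) and a number 7.7 percentage points lower from compound 1 to compound 4 (within the scatter), so a carbonyl on this carbon is not needed to reach that lower level. Of the four groups, only carboxy stands apart, and nothing available here bears on why.

Still open, as far as these compounds go, is whether the higher level requires carboxy itself. A primary amide, a tetrazole or a hydroxymethyl group on this carbon would test that, and a pyridyl group would extend the comparison with phenyl.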